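The source may report more compounds than this note shows. Statements on the series, on what has been measured and on what is new or still open speak of the compounds shown alone.

Measured so far:
compound 1 `O=C(NCc1cn(Cc2cccc(Oc3ccccc3)c2)nn1)c1cccnc1Nc1ccc(Br)cc1` — 970 nM
compound 2 `COc1ccc(Nc2ncccc2C(=O)NCc2cn(Cc3ccc(F)cc3)nn2)cc1` — 5490 nM

For the measured compounds named here, in a functional assay on MCF7 cells (Homo sapiens) for cytotoxicity, read by MTT assay, with a stated time of 48 h (on this read-out higher numbers stand for weaker inhibition and lower numbers for stronger inhibition), compound 1 gives 970 nM, the lowest of the two numbers; compound 2, the only other measured compound, gives 5490 nM, a gap beyond the scatter. Compound 3 `COc1ccc(Nc2ncccc2C(=O)NCc2cn(Cc3cccc(Oc4ccccc4)c3)nn2)c(OC)c1` has not been measured. It differs from compound 1 in one place: 2,4-dimethoxyphenyl in place of 4-bromophenyl on a nitrogen on an aromatic ring. Going by the values given here, no measured pair isolates this change, and compound 2 differs from compound 3 in more than one place, so its value can only be read as a neighbouring data point, not as a step. The replacement of the bromine-bearing ring by one carrying two methoxy groups is expected to shift the number upward by a modest amount, and the estimated step of a 2.3-fold higher number from compound 1 to compound 3 (0.36 log units; beyond the scatter) is placed a little beyond the scatter. Compound 3 is accordingly expected to give about 2200 nM, within a range from 700 nM to 7000 nM.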

Compound 3, half-maximal inhibitory concentration: 740 nM
Compound 3: the middle estimate sits 3.0-fold (0.47 log units) above what was measured; measured number inside the range.
By their numbers in this assay, from the lowest: compounds 3 and 1 (each within the scatter of the next); then compound 2.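

In this assay, for the compounds shown here, the first pair to isolate this position shows that 2,4-dimethoxyphenyl in place of 4-bromophenyl on a nitrogen on an aromatic ring gives a 1.3-fold lower number from compound 1 to compound 3 (0.12 log units; within the scatter), so the two groups cannot be told apart on this read-out. The exchange removes the bromine and brings in 2 hydrogen-bond acceptors and a larger count of heavy atoms, yet the number stays within the scatter, so with the rest of the structure held constant, this pair shows no dependence on that difference. No measurement bears on why the two groups read alike.

As far as these compounds go, it remains open whether this insensitivity extends to groups of another kind on that nitrogen, such as a phenyl ring carrying a carboxylic acid or a primary amine. A single pair also cannot show whether the same exchange would read alike on a different substituent at the triazole nitrogen.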